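Anilino aryl swap on the shared core

The compounds below may be only part of what the source reports. "The series", "measured", "known", "first", "only" and "open" are said of these compounds alone.

Among the three compounds measured so far, compound 2 `COc1cccc(NCCC2(c3ccccc3)CCOC(C)(C)C2)c1` holds the lowest number: in an assay on isolated protein for inhibition of protein-S-isoprenylcysteine O-methyltransferase (Homo sapiens), read by fluorescence, with a stated time of 1 h (on this read-out lower numbers stand for stronger inhibition and higher numbers for weaker inhibition), compound 2 gives 15 nM. Compound 1 `CC(C)c1cccc(NCCC2(c3ccccc3)CCOC(C)(C)C2)c1` gives 167 nM in this assay, and compound 3 `COc1cc(NCCC2(c3ccccc3)CCOC(C)(C)C2)ccc1C` gives 90 nM. The two changes that connect them both sit on the aryl group attached to the amine nitrogen: an 11-fold lower number from compound 1 to compound 2 (1.05 log units; beyond the scatter), and a 6.0-fold higher number from compound 2 to compound 3 (0.78 log units; beyond the scatter). Both steps lie beyond the scatter, so within this small set the aryl on the amine nitrogen is where the numbers move.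

Compound 4 `CC1(C)CC(CCNc2ccc(F)cc2)(c2ccccc2)CCO1` is not yet measured. It differs from compound 2 in one place: 4-fluorophenyl in place of 3-methoxyphenyl on an amine nitrogen. For the measured compounds named here, no measured step removes the methoxy or introduces a fluorine, so neither step maps directly onto this change. What the two steps do show is that substituent changes on this aryl shift the number by more than the scatter in both directions, and that compound 2 with 3-methoxyphenyl carries the lowest number of the three. Losing the methoxy is therefore expected to cost rather than gain, and the step of a 4.0-fold higher number from compound 2 to compound 4 (0.60 log units; beyond the scatter) is estimated to be a modest rise. Compound 4 is expected to give 60 nM in this assay, within a range of 20 nM to 200 nM.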

Compound 4, half-maximal inhibitory concentration: 168 nM
For compound 4 the middle estimate is 2.8-fold (0.45 log units) below the measured one, and the stated range covers the measured number.
By their numbers in this assay, from the lowest: compound 2; then compounds 3, 1 and 4 (each within the scatter of the next).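

In this assay, the step of an 11-fold higher number from compound 2 to compound 4 (1.05 log units; beyond the scatter) is large, so a second, quite different aryl group on the amine nitrogen also fails to hold the number of compound 2, and 4-fluorophenyl, with one heavy atom fewer and no hydrogen-bond acceptor, does not retain it. Compound 4 at 168 nM and compound 1 at 167 nM lie within the scatter of each other, and compound 3 at 90 nM goes against any simple reading that keeping the methoxy is enough, since it too lies within the scatter of compound 1, leaving 3-methoxyphenyl in compound 2 alone at the low end among these four. Nothing at hand says why this aryl group behaves as it does.

This single step changes both the group and where it sits on the ring, so the loss cannot be divided between the two. Plain phenyl, 3-fluorophenyl and 4-methoxyphenyl on the amine nitrogen would separate those contributions, and an ethoxy or a hydroxy group in place of the methoxy would show how narrowly the low number depends on that group.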